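Removing the side chain entirely: compound 3 to compound 4

The source may hold more compounds than are shown below. What is called first, only, known or untested is meant among the compounds shown, and "the series" means these compounds.

Compound 3 `CCCCc1ccc(CN(CC)S(C)(=O)=O)c(=O)n1Cc1ccc(-c2ccccc2-c2nn[nH]n2)cc1` gives 2 nM in a functional assay (aorta) for antagonist activity, with Oryctolagus cuniculus as the target; on this read-out higher numbers stand for weaker inhibition and lower numbers for stronger inhibition. Among the compounds with values here, on the numbers so far it stands level with compound 2 `CCCCc1ccc(CNC(=O)N(C)C)c(=O)n1Cc1ccc(-c2ccccc2-c2nn[nH]n2)cc1`, which gives 2 nM, the two together being the lowest of the three; the furthest point is compound 1 `CCCCc1ccc(CNC(=O)Nc2ccccc2)c(=O)n1Cc1ccc(-c2ccccc2-c2nn[nH]n2)cc1`, which gives 30 nM, a step of a 15-fold lower number from compound 1 to compound 3 (1.18 log units; beyond the scatter). The step of no change at the digits printed from compound 2 to compound 3 (within the scatter) shows that exchanging one side chain for the other on this carbon makes no difference beyond the scatter, while a 15-fold lower number from compound 1 to compound 2 (1.18 log units; beyond the scatter) shows that the nature of the side chain can matter a great deal. Compound 4 `CCCCc1cccc(=O)n1Cc1ccc(-c2ccccc2-c2nn[nH]n2)cc1` goes further than any of these: the change is hydrogen in place of (ethyl(methylsulfonyl)amino)methyl on an aromatic carbon, so the substituent is not exchanged but removed altogether. Within the data shown here, no measured step covers a removal of this kind, and the three measured compounds all carry a side chain here. As far as these compounds go, the expectation is therefore uncertain, leaning towards a higher number, since every step that altered this group moved the read-out and the bare core is unknown. For compound 4 an estimate of 40 nM is made, with a range from 5 nM to 400 nM. This corresponds to an expected step of a 20-fold higher number from compound 3 to compound 4 (1.30 log units; beyond the scatter).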

Compound 4, half-maximal inhibitory concentration: 4 nM
Compound 4: middle estimate off by 10-fold (1.00 log units), on the high side; measured number outside the range, below it.
By their numbers in this assay, from the lowest: compounds 2, 3 and 4 (each within the scatter of the next); then compound 1.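

In this assay, the bare aromatic carbon stays within the scatter of both smaller side chains (the step reads a 2.0-fold higher number from compound 3 to compound 4 (0.30 log units; within the scatter), and the other reads a 2.0-fold higher number from compound 2 to compound 4 (0.30 log units; within the scatter)). The read-out at this position therefore needs neither (ethyl(methylsulfonyl)amino)methyl nor ((dimethylcarbamoyl)amino)methyl, and compound 1 is the one that stands apart, since hydrogen in place of ((phenylcarbamoyl)amino)methyl gives a step beyond the scatter (a 7.5-fold lower number from compound 1 to compound 4 (0.88 log units; beyond the scatter)). Nothing on hand explains why these side chains are tolerated to different degrees.

Open, as far as these compounds go, is how a carboxylic acid, a primary aminomethyl or a plain methyl on this carbon would read against compound 4. Also open, from the compounds shown here alone, is whether a benzyl or cyclohexyl group in place of the phenyl of compound 1 would give a similar number.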